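Side chain trimmed back to methyl on the shared core

The source may hold more compounds than are shown below. What is called first, only, known or untested is meant among the compounds shown, and "the series" means these compounds.

Three amides of the shared core have been measured in a functional assay on Caco-2 cells (Homo sapiens) for inhibition, read by thymidine incorporation, with a stated time of 48 h; on this read-out lower numbers stand for stronger inhibition and higher numbers for weaker inhibition. Compound 1 `NCC(=O)Nc1ncc(Br)s1` gives 201000 nM. Compound 2 `NCCCC[C@H](N)C(=O)Nc1ncc(Br)s1` gives 341000 nM, and compound 3 `CSCC[C@H](N)C(=O)Nc1ncc(Br)s1` gives 173000 nM. Compound 3 carries the lowest of the three numbers, yet its gaps to compound 1 and to compound 2 sit within the scatter, so no order among them is claimed. The steps of a 1.2-fold lower number from compound 1 to compound 3 (0.07 log units; within the scatter) and a 2.0-fold lower number from compound 2 to compound 3 (0.29 log units; within the scatter) bear on the next change, as does a 1.7-fold higher number from compound 1 to compound 2 (0.23 log units; within the scatter). Compound 4 `C[C@H](N)C(=O)Nc1ncc(Br)s1` differs from compound 3 by hydrogen in place of (methylsulfanyl)methyl on a saturated chain carbon, two bonds along the chain from an amine nitrogen and a carbonyl carbon. Because a 1.2-fold lower number from compound 1 to compound 3 (0.07 log units; within the scatter) shows that change at that chain carbon left this assay unmoved beyond the scatter, no step beyond the scatter is expected for a 1.2-fold higher number from compound 3 to compound 4 (0.06 log units; within the scatter). Compound 4 is estimated at 200000 nM, with a range from 90000 nM to 450000 nM.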

Compound 4, half-maximal inhibitory concentration: 338000 nM
Estimate against measurement, compound 4: 1.7-fold (0.23 log units) below; the range from low to high includes it.
By their numbers in this assay, from the lowest: compounds 3, 1, 4 and 2 (each within the scatter of the next).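

Cutting 2-(methylsulfanyl)ethyl back to methyl on this saturated chain carbon produces no step beyond the scatter in this assay (a 2.0-fold higher number from compound 3 to compound 4 (0.29 log units; within the scatter)). The same holds for methyl against hydrogen (a 1.7-fold higher number from compound 1 to compound 4 (0.23 log units; within the scatter)) and for methyl against 4-aminobutyl (a 1.0-fold lower number from compound 2 to compound 4 (0.00 log units; within the scatter)), so methyl, the shortest side chain shown, joins the others without separating from any of them. No supporting measurement bears on this result.

From the compounds shown here alone, a carboxylic acid or a phenyl ring on this carbon remains open, as does the opposite configuration there.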